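A few compounds are considered here, and "the series" means these few. Any claim that something is new, unique, unknown or untested is made for them only; others in the source may bear on it.

Measured so far:
Compound 1, `CCC(CC)O[C@@H]1C=C(C(=O)O)C[C@H](NCc2ccc(OC)cc2)[C@H]1NC(C)=O`, in an ADME assay on cells (Fibroblast, Gallus gallus) for cytotoxicity, read by CCK-8 assay, with a stated time of 48 h (on this read-out lower numbers stand for higher toxicity in this test and higher numbers for lower toxicity in this test), gives only a limit, > 200000 nM.
Compound 2, `CCC(CC)O[C@@H]1C=C(C(=O)O)C[C@H](NCc2ccc(Oc3ccccc3)cc2)[C@H]1NC(C)=O`, in this assay also gives only a limit, > 200000 nM.
Compound 3, `CCC(CC)O[C@@H]1C=C(C(=O)O)C[C@H](NCc2cccc(SC3CCCC3)c2)[C@H]1NC(C)=O`, in this assay likewise gives only a limit, > 200000 nM.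

Compound 2 therefore stands at the edge of what this assay can report: none of the three compounds shows measurable toxicity toward these cells, and all sit at the same point, (the limit of > 200000 nM in this assay, at which 3 of the 3 values shown sit). Among the measured compounds shown here, the single one-point step among the measured compounds, a step that the two limits leave unreadable from compound 1 to compound 2, is not readable, since both of its ends are limits, so its size and direction stay unknown.

Compound 4, `CCC(CC)O[C@@H]1C=C(C(=O)O)C[C@H](NCc2ccc(-c3ccc4sccc4c3)cc2)[C@H]1NC(C)=O`, differs from compound 2 in one place: 1-benzothiophen-5-yl in place of phenoxy on an aromatic carbon. For the measured compounds named here, no measured step gives a readable size for a change of this kind, and the only comparable step is the unreadable one from compound 1 to compound 2. With every measured compound sitting at the limit, the expectation for compound 4 is that it too will show no toxicity within the tested range, giving an expected step that the limit leaves unreadable from compound 2 to compound 4, which is not beyond the scatter. Compound 4 is therefore estimated at 250000 nM, with a range from 120000 nM to 600000 nM, and most likely reported as a limit rather than a number.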

Compound 4, half-maximal cytotoxic concentration: > 200000 nM
Compound 4 was reported as a limit; the forecaster's own chance of this, stated with the estimate: 80%; the middle value is on the limit's open side.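

No new step can be read: compound 4, like compound 1 and compound 2, is reported only as a limit, so its steps from those two compounds have no readable size. All the values shown share one point: the limit of > 200000 nM in this assay, at which 4 of the 4 values shown sit.

The compounds shown leave open at what concentration, if any, each would harm these cells in this assay, and whether 1-benzothiophen-5-yl in place of phenoxy changes that at all.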